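Swapping the benzyl group on a shared triazolopyrimidine-type core

The source may hold more compounds than are shown below. What is called first, only, known or untested is meant among the compounds shown, and "the series" means these compounds.

Of the compounds shown here, three sharing one core have been tested in a functional assay on BGC-823 cells (Homo sapiens) for inhibition, read by MTT assay, with a stated time of 72 h; a lower number here means a stronger inhibitor, a higher number a weaker inhibitor. Compound 1 `C[C@@H]1CCN(c2cc(-c3ccccc3)nc3ncnn23)C[C@@H]1N(C)c1ncnc2[nH]ccc12` carries a phenyl group on the core and gives only the limit > 100000 nM, so for compound 1 no number is available. Compound 2 `Cc1cc(N2CC[C@@H](C)[C@@H](N(C)c3ncnc4[nH]ccc34)C2)n2nc(SCc3ccccc3Br)nc2n1` carries a (2-bromobenzyl)sulfanyl group and gives 81100 nM. Compound 3 `CCCCCc1c(C)nc2nc(SCc3ccc(Cl)cc3)nn2c1N1CC[C@@H](C)[C@@H](N(C)c2ncnc3[nH]ccc23)C1` carries a (4-chlorobenzyl)sulfanyl group together with a pentyl chain and gives 32300 nM. Among the two measured numbers, compound 2 is the higher, which means the weaker inhibitor, and the gap between compound 2 and compound 3 is larger than the usual scatter, while compound 1 sits at the limit of > 100000 nM in this assay, at which 1 of the 3 values shown sits.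

The next compound, compound 4 `Cc1cc(N2CC[C@@H](C)[C@@H](N(C)c3ncnc4[nH]ccc34)C2)n2nc(SCc3ccc(C(F)(F)F)cc3)nc2n1`, differs from compound 2 in one place only: 4-(trifluoromethyl)phenyl in place of 2-bromophenyl on a saturated chain carbon bound to a sulfur. For the measured compounds named here, no measured pair in this set isolates exactly this change, so the expectation rests on the weak inhibition of compound 2 at 81100 nM and on compound 3 being somewhat stronger with its own 4-substituted benzyl group. The step expected is a 1.6-fold lower number from compound 2 to compound 4 (0.21 log units; within the scatter), a small gain that may not rise clearly above the scatter. Compound 4 is therefore expected to give about 50000 nM in this assay, with a plausible range from 15000 nM to 150000 nM.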

Compound 4, half-maximal inhibitory concentration: 23300 nM
Compound 4: middle estimate off by 2.1-fold (0.33 log units), on the high side; low and high end bracket the measured number.
By their numbers in this assay, from the lowest: compounds 4 and 3 (each within the scatter of the next); then compound 2. At a limit, above all of these: compound 1.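

For the compounds shown here, the swap of 2-bromophenyl for 4-(trifluoromethyl)phenyl on a saturated chain carbon bound to a sulfur is the first change here that can be read on its own, as compound 2 and compound 4 differ in that one place and share everything else. In this assay the swap gives a 3.5-fold lower number from compound 2 to compound 4 (0.54 log units; beyond the scatter) and so shows that the number responds to what is attached at this position, although the gain is modest and compound 4 still needs 23300 nM to reach half-maximal inhibition. Nothing measured in this set explains why this swap lowers the number.

The swap replaces the bromine with a trifluoromethyl group and also moves the substituent from the 2-position to the 4-position of the ring, so the pair cannot say which of the two matters: 4-bromobenzyl or 2-(trifluoromethyl)benzyl would separate them. Going by these compounds, it also remains open how this position would respond to an unsubstituted benzyl group, or to a benzyl group carrying an amine or a carboxylic acid.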